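The source may hold more compounds than are shown below. What is called first, only, known or untested is meant among the compounds shown, and "the series" means these compounds.

In a physicochemical assay for lipophilicity, read by HPLC, measured as octanol-water partition (a lower number here means a more polar compound, a higher number a more lipophilic compound), compound 1 `COc1ccc(N(CC(=O)NCCC[Te]c2ccccc2)C(=O)CNC(=O)OC(C)(C)C)cc1` gives 4.2, and compound 2 `COc1ccc(N(CC(=O)NCCC[Se]c2ccccc2)C(=O)CNC(=O)OC(C)(C)C)cc1` gives 3.3, the lower of the two. For the measured compounds named here, the only measured change, a number 0.90 log units lower from compound 1 to compound 2 (beyond the scatter), concerns the chalcogen and leaves the acyl group untouched. Compound 3 `COc1ccc(N(CC(=O)NCCC[Se]c2ccccc2)C(=O)C#Cc2ccccc2)cc1` differs from compound 2 by 2-phenylethynyl in place of ((tert-butoxycarbonyl)amino)methyl on a carbonyl carbon. Going by the values given here, no measured step bears on this change, so the expectation rests on the structural change alone. For compound 3 the step is estimated as a number 0.60 log units higher from compound 2 to compound 3 (beyond the scatter), an upward move in this assay. Compound 3 is therefore expected to give about 3.9, within a range of 3.3 to 4.5.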

Compound 3, partition coefficient: 2.6
Estimate against measurement, compound 3: 1.30 log units above, and the stated range ends above it.
By their numbers in this assay, from the lowest: compound 3; then compound 2; then compound 1.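

On a carbonyl carbon whose other neighbour is an amide-type nitrogen, 2-phenylethynyl in place of ((tert-butoxycarbonyl)amino)methyl gives a number 0.70 log units lower from compound 2 to compound 3 (beyond the scatter) in this assay, so the acyl group, untouched in the earlier pair, also moves this number. Compound 3 now stands lowest of the three. No measurement here accounts for the direction of this step.

Still open, on these data alone, is whether the step belongs to the triple bond, the aromatic ring or the departing carbamate, which a 2-phenylethyl or aminomethyl group on the same carbonyl carbon would help separate. Also open, as far as these compounds go, is whether it holds with tellurium in place of selenium.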